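Chloro-methyl anilide and mouse liver microsomal clearance

The source may hold more compounds than are shown below. What is called first, only, known or untested is meant among the compounds shown, and "the series" means these compounds.

Measured compounds:
compound 1, `Cc1ccc(NC(=O)[C@H]2CN(C)C[C@@H]2c2ccc(/C=C/C(=O)Nc3ccccc3N)cc2)cc1`, 62 mL/min/kg
compound 2, `CC(C)c1ccc(NC(=O)[C@H]2CN(C)C[C@@H]2c2ccc(/C=C/C(=O)Nc3ccccc3N)cc2)cc1`, 54 mL/min/kg

In an in vitro ADME assay on microsomes from liver (Mus musculus) for pharmacokinetics, read by LC-MS, with a stated time of 10 min, tested at 1 uM (a lower number here means slower removal, a higher number faster removal of the compound), compound 1 gives 62 mL/min/kg, the highest of the two numbers shown; its nearest neighbour is compound 2, and the step of a 1.1-fold lower number from compound 1 to compound 2 (0.06 log units; within the scatter) stays within the scatter, so no order between them can be read from these data. The unmeasured compound 3, `Cc1cc(NC(=O)[C@H]2CN(C)C[C@@H]2c2ccc(/C=C/C(=O)Nc3ccccc3N)cc2)ccc1Cl`, differs from compound 1 by 4-chloro-3-methylphenyl in place of 4-methylphenyl on an amide-type nitrogen. For the measured compounds named here, the one measured step bears on it only loosely: a change of the group on the same aromatic ring, from compound 1 to compound 2, left the clearance where it was. On that basis no step beyond the scatter is expected for compound 3 in this assay, in either direction. Compound 3 is therefore estimated at 60 mL/min/kg, with a range from 35 mL/min/kg to 100 mL/min/kg, which means an expected step of a 1.0-fold lower number from compound 1 to compound 3 (0.01 log units; within the scatter).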

Compound 3, clearance: 65 mL/min/kg
Compound 3: the middle estimate sits 1.1-fold (0.03 log units) below what was measured, within the range that was stated.
By their numbers in this assay, from the lowest: compounds 2, 1 and 3 (each within the scatter of the next).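

In this assay, 4-chloro-3-methylphenyl in place of 4-methylphenyl on the amide-type nitrogen gives a 1.0-fold higher number from compound 1 to compound 3 (0.02 log units; within the scatter), so a group carrying chlorine as well as methyl now joins the alkyl-only change seen earlier in leaving the clearance unresolved. Set against the 4-isopropylphenyl group, the same group gives a 1.2-fold higher number from compound 2 to compound 3 (0.08 log units; within the scatter), and the three groups shown at this position cannot be told apart by clearance. Nothing at hand accounts for this result.

From the compounds shown here alone, all three compounds carry only alkyl or chloro groups on this phenyl ring, so it remains open whether an amine or a carboxylic acid there would take the clearance beyond the scatter. Going by these compounds, it also remains open how far the clearance depends on the shared core, which does not vary among them.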